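This account rests on a few compounds, and the source may have more. Where it says the series, first, only, none or still open, it means among the compounds named here.

Measured in a functional assay on MCF7 cells (Homo sapiens) for inhibition, read by MTT assay, with a stated time of 24 h; a lower number here means a stronger inhibitor, a higher number a weaker inhibitor:
compound 1 `CCOC(=O)C1=Cc2ccccc2OC1(OCc1cn(-c2ccc(F)cc2)nn1)C(F)(F)F` – 9100 nM
compound 2 `O=C(O)C1=Cc2ccccc2OC1(OCc1cc(-c2ccc(F)cc2)no1)C(F)(F)F` – 64200 nM
compound 3 `CCOC(=O)C1=Cc2ccccc2OC1(OCc1cc(-c2ccc(OC)cc2)no1)C(F)(F)F` – a limit only, > 150000 nM

Of the two numbers given, compound 1 holds the lower one, 9100 nM; compound 2 sits at a higher number, 64200 nM, a gap beyond the scatter of this assay. For compound 3 the result is only a limit of the read-out, > 150000 nM, as noted in the limit of > 150000 nM in this assay, at which 1 of the 3 values shown sits. Compound 4 `CCCCCCCCn1cc(COC2(C(F)(F)F)Oc3ccccc3C=C2C(=O)OCC)nn1` has not yet been measured in this assay. It differs from compound 1 in one place: octyl in place of 4-fluorophenyl on an aromatic nitrogen. Among the compounds with values here, no step between measured compounds covers this change, so its effect is open; a step of modest size in either direction is expected, with no firm lean. Compound 4 is estimated at 8000 nM, between 2500 nM and 30000 nM, an expected step of a 1.1-fold lower number from compound 1 to compound 4 (0.06 log units; within the scatter).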

Compound 4, half-maximal inhibitory concentration: > 150000 nM
Compound 4: no number, only a limit (the forecaster's own chance of this, stated with the estimate: 10%); middle value at least 18-fold (1.27 log units) from the limit.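

In this assay, the aromatic nitrogen proves to be a sensitive position: octyl in place of 4-fluorophenyl gives an at least 16-fold higher number from compound 1 to compound 4 (1.21 log units; beyond the scatter), the first step read at this position. Compound 4 gives > 150000 nM, which is a limit and not a number: the limit of > 150000 nM in this assay, at which 2 of the 4 values shown sit.

The compounds shown leave open whether the loss tracks the missing aromatic ring or the octyl chain itself. A shorter chain such as butyl, or a benzyl group, on that nitrogen would separate these two readings.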